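The source may report more compounds than this note shows. Statements on the series, on what has been measured and on what is new or still open speak of the compounds shown alone.

In a functional assay on HCC1937 cells (Homo sapiens) for inhibition, read by MTT assay, with a stated time of 48 h (on this read-out lower numbers stand for stronger inhibition and higher numbers for weaker inhibition), three compounds have been measured. Compound 1 `CCN1CCN(c2ncc3c(n2)CCN(C(=O)c2cc(Cc4n[nH]c(=O)c5ccccc45)ccc2F)C3)CC1` gives 137000 nM, and compound 2 `O=C(c1cc(Cc2n[nH]c(=O)c3ccccc23)ccc1F)N1CCc2nc(N3CCCC3)ncc2C1` gives 7810 nM. Compound 3 `O=C(c1cc(Cc2n[nH]c(=O)c3ccccc23)ccc1F)N1CCc2nc(N3CCCCC3)ncc2C1` is known only as a limit. For compound 3 that limit is > 200000 nM, a floor of the assay rather than a number, namely (the limit of > 200000 nM in this assay, at which 1 of the 3 values shown sits). The step of an at least 25-fold higher number from compound 2 to compound 3 (1.40 log units; beyond the scatter) is large, whereas an at least 1.4-fold higher number from compound 1 to compound 3 (0.16 log units; that floor lies within the scatter) stays within the scatter.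

Compound 4 `CN(C)CCN(C)c1ncc2c(n1)CCN(C(=O)c1cc(Cc3n[nH]c(=O)c4ccccc34)ccc1F)C2` differs from compound 3 by (2-(dimethylamino)ethyl)(methyl)amino in place of piperidin-1-yl on an aromatic carbon. The entering group, like 4-ethylpiperazin-1-yl in compound 1, carries a second amine nitrogen, and compound 1 and compound 3 are within the scatter of each other. Compound 4 is therefore expected to remain near the weak end, with an estimated 110000 nM (range 25000 nM to 250000 nM). The expected step of an at least 1.8-fold lower number from compound 3 to compound 4 (0.25 log units; that floor lies within the scatter) is thus modest at most.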

Compound 4, half-maximal inhibitory concentration: > 200000 nM
Compound 4 gave a limit, no number (the forecaster's own chance of this, stated with the estimate: 35%); at least 1.8-fold (0.25 log units) between middle value and limit.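

In this assay, the loss seen with piperidin-1-yl also appears with a group that has no ring, (2-(dimethylamino)ethyl)(methyl)amino, giving an at least 25-fold higher number from compound 2 to compound 4 (1.40 log units; beyond the scatter). Against the ethylpiperazine of compound 1, the result is an at least 1.4-fold higher number from compound 1 to compound 4 (0.16 log units; that floor lies within the scatter). Compound 3 and compound 4 both sit at a limit, not a number, and the step between them cannot be read: the limit of > 200000 nM in this assay, at which 2 of the 4 values shown sit.

The compounds shown leave open whether azetidin-1-yl or morpholin-4-yl on this aromatic carbon would stay near compound 2 or also fall to the limit.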